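Terminal group on the ethyl chain: thiazolylsulfanyl, hydroxy, carboxymethyl

A few compounds are considered here, and "the series" means these few. Any claim that something is new, unique, unknown or untested is made for them only; others in the source may bear on it.

Measured compounds:
compound 1 `O=c1c2ccccc2c(-c2cccnc2)nn1CCSc1nccs1` — 97%
compound 2 `O=c1c2ccccc2c(-c2cccnc2)nn1CCO` — 69%

In an assay on isolated protein (Oryctolagus cuniculus) with Thromboxane-A synthase (Homo sapiens) as the target, tested at 1 uM (on this read-out lower numbers stand for less inhibition and higher numbers for more inhibition at the one concentration tested (going by the name of the read-out)), compound 2 gives 69%, the lower of the two numbers; compound 1 gives 97%. The step of a number 28 percentage points lower from compound 1 to compound 2 (beyond the scatter) is the only one measured. Compound 3 `O=C(O)CCCn1nc(-c2cccnc2)c2ccccc2c1=O` carries the change (carboxymethyl in place of hydroxy on a saturated chain carbon, two bonds along the chain from an aromatic nitrogen). Within the data shown here, no measured step bears on a carboxymethyl at this place; the step from compound 1 to compound 2 shows only that this end of the chain moves the read-out. For compound 3 a modest rise in this assay is expected, a number 7 percentage points higher from compound 2 to compound 3 (within the scatter), with wide uncertainty. The estimate for compound 3 is 76%, between 45% and 98%.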

Compound 3, a percentage reported as inhibition, at one concentration (the size of the read-out at that concentration, not a potency): 73%
Beside the measured number, compound 3's estimate is 3 percentage points above it; the range from low to high includes it.
By their numbers in this assay, from the lowest: compounds 2 and 3 (each within the scatter of the next); then compound 1.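

In this assay, exchanging hydroxy for carboxymethyl at this place gives a number 4 percentage points higher from compound 2 to compound 3 (within the scatter), so this pair of chain ends is not separated. The (1,3-thiazol-2-yl)sulfanyl end keeps its distance from the carboxymethyl end as well, with a number 24 percentage points lower from compound 1 to compound 3 (beyond the scatter), and compound 1 stands apart from both other compounds. Nothing in the data shown accounts for these steps.

From the compounds shown here alone, whether the sulfur or the thiazole ring of compound 1 matters more remains open, and a phenylsulfanyl or methylsulfanyl end would address this. Going by these compounds, an amine at the chain end and a longer chain carrying the (1,3-thiazol-2-yl)sulfanyl group also remain open.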